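Swapping an amide for a sulfonamide on a weak inhibitor

The source may report more compounds than this note shows. Statements on the series, on what has been measured and on what is new or still open speak of the compounds shown alone.

The compounds share one core, seen in compound 2 `Cc1ccc(CN2CCC=C(CCC(=O)NO)C2=O)cc1`, which carries a methyl on its aromatic ring; in a functional assay on HCT-15 cells (Homo sapiens) for inhibition, read by sulforhodamine B assay (a lower number here means a stronger inhibitor of growth, a higher number a weaker inhibitor of growth), compound 2 gives 8510 nM. Compound 1 `CC(=O)Nc1ccc(CN2CCC=C(CCC(=O)NO)C2=O)cc1` has an acetamido group there; in this assay compound 1 gives "not determined" (no result reported). Compound 3 `O=C(CCC1=CCCN(Cc2ccc(NC(=O)c3ccccc3)cc2)C1=O)NO` carries benzamido in place of methyl on an aromatic carbon. In this assay compound 3 reaches only a limit, > 10000 nM. That limit, (the limit of > 10000 nM in this assay, at which 1 of the 3 values shown sits), is the sole anchor for compound 3 among the numbers shown. For the measured compounds named here, the one measured step, an at least 1.1-fold higher number from compound 2 to compound 3 (0.07 log units; that floor lies within the scatter), runs from a number to a limit, so its size is known only as a floor.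

Compound 4 `Cc1ccc(S(=O)(=O)Nc2ccc(CN3CCC=C(CCC(=O)NO)C3=O)cc2)cc1` differs from compound 3 by (4-methylphenyl)sulfonyl in place of benzoyl on a nitrogen on an aromatic ring. Going by the values given here, no measured step touches this group; the step from compound 2 to compound 3 bears only on the same place on the ring. Among the compounds with values here, compound 3 already sits at a limit, and the only related step is small, so the expected step is a number no higher from compound 3 to compound 4 (the limit leaves the size open), none beyond the scatter. In this assay compound 4 is therefore estimated at 10000 nM, within a range from 4000 nM to 25000 nM.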

Compound 4, concentration for 50% growth inhibition: > 10000 nM
Compound 4: no number, only a limit; the forecaster's own chance of this, stated with the estimate: 55%; the middle value sits exactly at the limit.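

In this assay compound 4 gives > 10000 nM, which is a limit. No step can be read between compound 3 and compound 4, because both stop at the same limit: the limit of > 10000 nM in this assay, at which 2 of the 4 values shown sit.

From the compounds shown here alone, whether benzoyl or (4-methylphenyl)sulfonyl on that nitrogen gives the stronger inhibitor of growth stays open, as does how far either compound lies beyond the limit.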